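Turning a methoxypropyl amide into a carboxypiperidine amide

This account rests on a few compounds, and the source may have more. Where it says the series, first, only, none or still open, it means among the compounds named here.

Of the compounds shown here, two have been measured in an in vitro assay on BHK cells for inhibition of Glucagon receptor (Homo sapiens); on this read-out lower numbers stand for stronger inhibition and higher numbers for weaker inhibition. Compound 1, `O=C(O)CCNC(=O)c1ccc(CN(C(=O)Nc2cc(Cl)cc(Cl)c2)c2ccc(C3=CCCCC3)cc2)cc1`, gives 27 nM in this assay. Compound 2, `COCCCNC(=O)c1ccc(CN(C(=O)Nc2ccc(OC(F)(F)F)cc2)C2CCC(C(C)(C)C)CC2)cc1`, reaches only a limit of this assay, > 10000 nM. This limit is the limit of > 10000 nM in this assay, at which 1 of the 2 values shown sits, so for compound 2 no number is known, only that it lies beyond the range the assay reports.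

Compound 3, `CC(C)(C)C1CCC(N(Cc2ccc(C(=O)N3CCCC(C(=O)O)C3)cc2)C(=O)Nc2ccc(OC(F)(F)F)cc2)CC1`, is not yet measured. It keeps the whole of compound 2 apart from one change: 3-carboxypiperidin-1-yl in place of (3-methoxypropyl)amino on a carbonyl carbon. Among the measured compounds shown here, no measured pair shows this particular exchange, so its effect can only be estimated. Compound 1 and compound 2 stand far apart in this assay. The two of them differ in several places at once, so their pair does not single out any one change. The expected step of an at least 6.6-fold lower number from compound 2 to compound 3 (0.82 log units; beyond the scatter) is therefore a gain of uncertain size. Compound 3 is expected at 1500 nM, with a likely range from 150 nM to 15000 nM.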

Compound 3, half-maximal inhibitory concentration: 1000 nM
Compound 3: the middle estimate sits 1.5-fold (0.18 log units) above what was measured; the range from low to high includes it.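

In this assay, among the compounds shown here, putting 3-carboxypiperidin-1-yl in place of (3-methoxypropyl)amino on a carbonyl carbon gives an at least 10-fold lower number from compound 2 to compound 3 (1.00 log units; beyond the scatter), the first evidence that a change at this one place can move the read-out on its own. Compound 2 stands at a limit of the assay, > 10000 nM, which is not a number. The printed step is therefore only a lower bound on the gain, because its starting point is a limit: the limit of > 10000 nM in this assay, at which 1 of the 3 values shown sits.

The exchange brings in a ring and a carboxylic acid together, and the compounds shown do not separate the two. A plain piperidine without the acid, or the methyl ester of the acid, would show whether the ring, the acid or both carry the gain.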